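Closing the diethylamino chain into a pyrrolidine ring

The source may report more compounds than this note shows. Statements on the series, on what has been measured and on what is new or still open speak of the compounds shown alone.

Two chalcones built on the same core have been measured for lipophilicity. Compound 1, `COc1cc(OC)c(C(=O)/C=C/c2ccccc2)c(O)c1CN(C)C`, gives 1.61 in a physicochemical assay for lipophilicity, using the shake flask method, measured as octanol-water partition, with a stated time of 24 h, at pH 7.4; on this read-out higher numbers stand for higher lipophilicity and lower numbers for lower lipophilicity. Compound 2, `CCN(CC)Cc1c(OC)cc(OC)c(C(=O)/C=C/c2ccccc2)c1O`, gives 1.69 in this assay. Within the data shown here, the single step between them, a number 0.08 log units higher from compound 1 to compound 2 (within the scatter), exchanges diethylamino for dimethylamino on a saturated chain carbon bound to an aromatic carbon; on these two numbers compound 2 stands as the one measured so far whose nearest neighbour is compound 1, at a separation that counts as no real difference.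

Compound 3, `COc1cc(OC)c(C(=O)/C=C/c2ccccc2)c(O)c1CN1CCCC1`, is not yet measured. It differs from compound 2 by pyrrolidin-1-yl in place of diethylamino on a saturated chain carbon bound to an aromatic carbon. Among the measured compounds shown here, the only step on record, from compound 1 to compound 2, shows that swapping one small amine substituent for another of similar size hardly moved this assay. For the measured compounds named here, no measured pair speaks to closing an open chain into a ring. On that basis the step expected from compound 2 to compound 3 is a number 0.07 log units lower from compound 2 to compound 3 (within the scatter), a change not expected to exceed the scatter. The estimate for compound 3 in this assay is therefore 1.62, within 1.32 to 1.92.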

Compound 3, partition coefficient: 1.74
For compound 3 the middle estimate is 0.12 log units below the measured one; the range from low to high includes it.
By their numbers in this assay, from the lowest: compounds 1, 2 and 3 (each within the scatter of the next).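

In this assay, closing the open chain into a ring at this place, on a saturated chain carbon bound to an aromatic carbon, gives a number 0.05 log units higher from compound 2 to compound 3 (within the scatter), so pyrrolidin-1-yl and diethylamino, which share the same count of heavy atoms, cannot be told apart on this read-out. The ring also stays close to the dimethylamino group, with a number 0.13 log units higher from compound 1 to compound 3 (within the scatter), so all three amines shown, two open and one closed, lie within the usual scatter of one another, and none of the compounds goes against this. For these three compounds, then, neither the size of the open substituents nor the presence of a ring separates the numbers at this place, though no evidence at hand accounts for how closely they agree.

Going by these compounds, whether this holds for a larger ring, such as piperidine, or for a ring carrying a second hetero atom, such as morpholine, remains open. So does what a longer chain between the amine nitrogen and the aromatic carbon, or a carboxylic acid in place of the amine, would do to this read-out.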